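Pyridylsulfonyl piperidine amides as muscarinic M5 modulators

This account rests on a few compounds, and the source may have more. Where it says the series, first, only, none or still open, it means among the compounds named here.

Compound 1, `CCN(Cc1ccccc1)C(=O)C1CCN(S(=O)(=O)c2cccc3c2OCCO3)CC1`: > 10000 nM; > 10000 nM (2 entries)
Compound 2, `CCN(Cc1ccccc1)C(=O)C1CCN(S(=O)(=O)c2ccncc2)CC1`: > 10000 nM

In a functional assay on CHO cells for positive allosteric modulation of muscarinic acetylcholine receptor M5 (Homo sapiens), read by calcium flux (on this read-out higher numbers stand for an effect only at larger amounts of compound and lower numbers for an effect already at smaller amounts), compound 1 returns only a limit of the assay and not a number, > 10000 nM; > 10000 nM (2 entries), and this holds for both of its entries. In the same assay compound 2 likewise returns only a limit of the assay and not a number, > 10000 nM. Compound 2 therefore stands at the upper bound of what this assay can report, with one further entry that also gives no single number, a position described by the limit of > 10000 nM in this assay, at which 1 of the 2 values shown sits.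

Compound 3, `CCN(Cc1ccccc1)C(=O)C1CCN(S(=O)(=O)c2cccnc2)CC1`, differs from compound 2 only in the change (pyridin-3-yl in place of pyridin-4-yl on a sulfonyl sulfur). Among the compounds with values here, with no measured step available between compounds, the step from compound 2 to compound 3 is expected to be none beyond the scatter, since both compounds measured so far sit at the limit; the estimated step is a step that the limit leaves unreadable from compound 2 to compound 3. Compound 3 is accordingly estimated at 12000 nM, within a range of 3000 nM to 50000 nM.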

Compound 3, half-maximal effective concentration: > 10000 nM
Compound 3 was reported as a limit; the forecaster's own chance of this, stated with the estimate: 80%; the middle value is on the limit's open side.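

Compound 2 and compound 3 each return only a limit of the assay and not a number, so no step between them can be read: the limit of > 10000 nM in this assay, at which 2 of the 3 values shown sit.

The compounds shown leave open whether pyridin-3-yl and pyridin-4-yl differ at all in this assay.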